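The compounds below may be only part of what the source reports. "The series", "measured", "known", "first", "only" and "open" are said of these compounds alone.

Compound 1 `CCCCCCOc1ccc(C(O)C2OC(=O)c3c(OC)cc(OC)cc32)cc1`: > 40000 nM
Compound 2 `COc1cc(OC)c2c(c1)C(C(O)c1ccc(OCc3ccc(F)cc3)cc1)OC2=O`: > 40000 nM
Compound 3 `COc1cc(OC)c2c(c1)C(C(O)c1ccc(OCc3ccc(Cl)cc3)cc1)OC2=O`: > 40000 nM

These three compounds were tested in an ADME assay on RAW264.7 cells (Mus musculus) for cytotoxicity, read by MTT assay, with a stated time of 24 h, in the absence of a further agent (on this read-out lower numbers stand for stronger inhibition and higher numbers for weaker inhibition), and none of them has yielded a number. In this assay compound 3 gives > 40000 nM, which is a limit of the assay. It shares that position with both of the other compounds: the limit of > 40000 nM in this assay, at which 3 of the 3 values shown sit.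

Compound 4 `COc1cc(OC)c2c(c1)C(C(O)c1ccc(OCc3ccc(Br)cc3)cc1)OC2=O` has not yet been measured. It carries bromo in place of chloro on an aromatic carbon, so that (4-chlorobenzyl)oxy becomes (4-bromobenzyl)oxy: bromo in place of chloro on an aromatic carbon. Within the data shown here, the closest precedent is the halogen exchange in a step that the two limits leave unreadable from compound 2 to compound 3. The two changes of the pentyl group, a step that the two limits leave unreadable from compound 1 to compound 2 and a step that the two limits leave unreadable from compound 1 to compound 3, are further removed from this exchange. None of these steps has a readable size, so none can supply a size or direction to carry over. The account therefore expects no step beyond the usual scatter in this assay, and a further report of a limit is the likeliest result. The expected change is a step that the limit leaves unreadable from compound 3 to compound 4. For compound 4 the estimated value is 50000 nM, with an expected range from 25000 nM to 100000 nM.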

Compound 4, half-maximal inhibitory concentration: > 40000 nM
Compound 4 gave a limit, no number (the forecaster's own chance of this, stated with the estimate: 85%); the middle value is on the limit's open side.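

No step can be read among compound 1, compound 2, compound 3 and compound 4 in this assay, since all four give a limit and none gives a number: the limit of > 40000 nM in this assay, at which 4 of the 4 values shown sit. The compounds shown leave open whether exchanging the halogen or replacing the pentyl group changes cytotoxicity at all, and by how much.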